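(4-Methylphenyl)sulfonyl in place of hydrogen: cytotoxicity outlook

A few compounds are considered here, and "the series" means these few. Any claim that something is new, unique, unknown or untested is made for them only; others in the source may bear on it.

Compound 1, `Cc1c(O)ccc2c1[C@H](Cn1cc(-c3ccc(Cl)cc3)nn1)[C@@]13CC(=O)[C@@](C)(CC[C@@H]21)C3`, in a functional assay on HL-60 cells (Homo sapiens) for cytotoxicity, read by MTT assay, with a stated time of 4 days (a higher number here means a weaker inhibitor, a lower number a stronger inhibitor), gives > 20000 nM, a limit of the assay.
Compound 2, `Cc1ccc(S(=O)(=O)Oc2ccc3c(c2C)[C@H](Cn2cc(-c4ccc(Cl)cc4)nn2)[C@@]24CC(=O)[C@@](C)(CC[C@@H]32)C4)cc1`, in this assay gives > 20000 nM, again a limit.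
Compound 3, `C=C1C[C@]23C[C@@]1(O)CC[C@H]2c1ccc(O)c(C)c1[C@@H]3Cn1cc(-c2ccccc2)nn1`, in this assay gives > 20000 nM, also a limit.

Compound 2 differs from compound 1 by (4-methylphenyl)sulfonyl in place of hydrogen on an oxygen on an aromatic ring. The step that the two limits leave unreadable from compound 1 to compound 2 cannot be read, because of the limit of > 20000 nM in this assay, at which 3 of the 3 values shown sit. The difference between the core of compound 3 and the core of compound 1 is not broken down here.

Compound 4, `C=C1C[C@]23C[C@@]1(O)CC[C@H]2c1ccc(OS(=O)(=O)c2ccc(C)cc2)c(C)c1[C@@H]3Cn1cc(-c2ccccc2)nn1`, has not yet been measured. It differs from compound 3 by (4-methylphenyl)sulfonyl in place of hydrogen on an oxygen on an aromatic ring, the same change as that from compound 1 to compound 2, made on the same kind of place. For the measured compounds named here, the only precedent for this change is unreadable, and the compound it starts from sits at the limit, so compound 4 is expected to sit at the limit as well, an expected step that the limit leaves unreadable from compound 3 to compound 4. In this assay compound 4 is estimated at 30000 nM, between 10000 nM and 100000 nM, most likely reported only as a limit.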

Compound 4, half-maximal inhibitory concentration: > 20000 nM
Compound 4: a limit, no number; the forecaster's own chance of this, stated with the estimate: 85%; the middle value is on the limit's open side.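

The step between compound 3 and compound 4 cannot be read, any more than the earlier one between compound 1 and compound 2, because none of these compounds gives a number: the limit of > 20000 nM in this assay, at which 4 of the 4 values shown sit. The compounds shown leave open whether (4-methylphenyl)sulfonyl in place of hydrogen on the oxygen changes cytotoxicity in this assay, since no compound here gives a measurable value.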